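Chloro added to the urea aryl ring

The source may hold more compounds than are shown below. What is called first, only, known or untested is meant among the compounds shown, and "the series" means these compounds.

The series shares one core; compound 1 is `COc1cc(-c2nn(-c3cccc(NC(=O)c4cccc(C(F)(F)F)c4)c3)cc2-c2ccncc2)ccc1Cl` and compound 2 is `COc1cc(-c2nn(-c3cccc(NC(=O)Nc4cccc(C(F)(F)F)c4)c3)cc2-c2ccncc2)ccc1Cl`. In a functional assay on RPMI-8226 cells (Homo sapiens) for inhibition, read by sulforhodamine B assay, with a stated time of 48 h (on this read-out lower numbers stand for higher toxicity in this test and higher numbers for lower toxicity in this test), compound 1 reaches only the limit > 50000 nM. In this assay compound 2 likewise reaches only the limit > 50000 nM. The step that the two limits leave unreadable from compound 1 to compound 2 therefore cannot be sized, as both values sit at the limit of > 50000 nM in this assay, at which 2 of the 2 values shown sit. Compound 3 is `COc1cc(-c2nn(-c3cccc(NC(=O)Nc4ccc(Cl)c(C(F)(F)F)c4)c3)cc2-c2ccncc2)ccc1Cl`; its difference from compound 2 is chloro in place of hydrogen on an aromatic carbon. Among the measured compounds shown here, no measured step bears on this change, and the only measured step is itself unreadable. No value here lies inside the measurable range, so nothing points to a step beyond the scatter in either direction, and compound 3 is expected to remain at or near the limit. The estimate for compound 3 in this assay is 50000 nM, with a range from 10000 nM to 200000 nM. The step of a number no higher from compound 2 to compound 3 (the limit leaves the size open) is thus expected to be small.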

Compound 3, concentration lethal to 50% of the cells: > 32500 nM
Compound 3: a limit, no number (the forecaster's own chance of this, stated with the estimate: 75%); the middle value is on the limit's open side.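

Compound 3 gives > 32500 nM in this assay, a limit and not a number. With compound 1 and compound 2 also at limits, neither step to compound 3 can be read. Going by these compounds, whether chloro in place of hydrogen on an aromatic carbon changes the read-out at all remains open.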